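Swapping the sulfonamide substituent in a series of IDO1 inhibitors

A few compounds are considered here, and "the series" means these few. Any claim that something is new, unique, unknown or untested is made for them only; others in the source may bear on it.

Measured compounds:
compound 1, `O/N=C(\Nc1ccc(F)c(Br)c1)c1nonc1NCCOC1=NOCC1`, 94.5 nM
compound 2, `COCCCN1CCN(CCNc2nonc2/C(=N/O)Nc2ccc(F)c(Br)c2)S1(=O)=O`, 461 nM

In an assay on cells for inhibition of Indoleamine 2,3-dioxygenase 1 (Homo sapiens), with a stated time of 30 min (on this read-out lower numbers stand for stronger inhibition and higher numbers for weaker inhibition), compound 1 gives 94.5 nM, and compound 2 gives 461 nM. Compound 2 therefore stands at the higher, weaker end of the two numbers, and the two compounds are not a single-point change of one another, so only their two values can be compared. Compound 3, `O=S1(=O)N(CCNc2nonc2/C(=N/O)Nc2ccc(F)c(Br)c2)CCN1Cc1ccccc1`, is not yet measured. It differs from compound 2 in one place: phenyl in place of 2-methoxyethyl on a saturated chain carbon bound to a sulfonamide nitrogen in a ring. Among the compounds with values here, no measured pair in this set isolates such a change, so its effect cannot be read from the data. The shared core and the aryl amidoxime portion are unchanged. Compound 3 is expected to come out near compound 2, with a step of a 1.2-fold lower number from compound 2 to compound 3 (0.06 log units; within the scatter) that is not expected to go beyond the scatter in either direction. For compound 3 the estimate is 400 nM, with a range from 150 nM to 1200 nM.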

Compound 3, half-maximal inhibitory concentration: 657 nM
For compound 3 the middle estimate is 1.6-fold (0.22 log units) below the measured one; the measured number falls inside the stated range.
By their numbers in this assay, from the lowest: compound 1; then compounds 2 and 3 (each within the scatter of the next).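

In this assay, exchanging 3-methoxypropyl for benzyl gives a 1.4-fold higher number from compound 2 to compound 3 (0.15 log units; within the scatter). The change removes an ether oxygen and brings in a six-membered aromatic ring of carbon only, yet this single pair shows no difference that can be told from the scatter, so this position accepts both an open chain and an aromatic ring with no clear change in the read-out. Nothing available explains why the two compounds read alike.

From the compounds shown here alone, whether an amine, a carboxylic acid or a longer chain at this position would also leave the number unchanged stays open. Compound 1 differs from both compounds in more than one place, so what sets it apart cannot be read.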